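Swapping the Terminal Amide of Compound 3

The compounds below may be only part of what the source reports. "The series", "measured", "known", "first", "only" and "open" are said of these compounds alone.

Compound 3 `CCOc1cc(NC(=O)CCCCCC(=O)Nc2ccccc2N)cc2c1OCC([N+](=O)[O-])=C2` stands at the weak end of this small set, and in a functional assay on PC-3 cells (Homo sapiens) for antiproliferative activity, read by MTT assay, with a stated time of 48 h (on this read-out higher numbers stand for weaker inhibition of growth and lower numbers for stronger inhibition of growth), compound 3 gives only a limit, > 20000 nM. In this assay compound 1 `CCOc1cc(NC(=O)CCCCCC(=O)Nc2cc(-c3ccccc3)ccc2N)cc2c1OCC([N+](=O)[O-])=C2` gives 7080 nM. In the same assay compound 2 `CCOc1cc(NC(=O)CCCCCCC(=O)Nc2ccccc2N)cc2c1OCC([N+](=O)[O-])=C2` gives 8630 nM. The two measured steps are an at least 2.8-fold higher number from compound 1 to compound 3 (0.45 log units; beyond the scatter) and an at least 2.3-fold higher number from compound 2 to compound 3 (0.36 log units; beyond the scatter). Both keep (2-aminophenyl)carbamoyl, so they bear on the new change only indirectly. Compound 4 `CCOc1cc(NC(=O)CCCCCNC(=O)CCCc2ccccc2)cc2c1OCC([N+](=O)[O-])=C2` carries ((3-phenylpropyl)carbonyl)amino in place of (2-aminophenyl)carbamoyl on a saturated chain carbon (((3-phenylpropyl)carbonyl)amino in place of (2-aminophenyl)carbamoyl on a saturated chain carbon, five bonds along the chain from a carbonyl carbon). A modest step toward stronger inhibition of growth, similar in size to those two, is expected, an at least 2.0-fold lower number from compound 3 to compound 4 (0.30 log units; that floor lies within the scatter). Compound 4 is estimated at 10000 nM, with an expected range of 4500 nM to 25000 nM.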

Compound 4, concentration for 50% growth inhibition: 7170 nM
Estimate against measurement, compound 4: 1.4-fold (0.14 log units) above; measured number inside the range.
By their numbers in this assay, from the lowest: compounds 1, 4 and 2 (each within the scatter of the next). At a limit, above all of these: compound 3.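

Putting ((3-phenylpropyl)carbonyl)amino in place of (2-aminophenyl)carbamoyl on this saturated chain carbon gives an at least 2.7-fold lower number from compound 3 to compound 4 (0.44 log units; beyond the scatter), so growth inhibition at this level does not depend on the (2-aminophenyl)carbamoyl group. Compound 3 gives only a limit: the limit of > 20000 nM in this assay, at which 1 of the 4 values shown sits. Set against ((2-aminophenyl)carbamoyl)methyl, the same group gives a 1.2-fold lower number from compound 2 to compound 4 (0.08 log units; within the scatter), so these two chain ends cannot be told apart here.

As far as these compounds go, whether a simple amine or a carboxylic acid on this chain carbon would hold the activity stays open, as does the effect of a longer chain in ((3-phenylpropyl)carbonyl)amino.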